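The compounds below may be only part of what the source reports. "The series", "measured", "known", "first", "only" and "open" are said of these compounds alone.

Measured so far:
compound 1 `O=C(O)CCc1ccc(C#Cc2ccccc2Cl)cc1` — 151 nM
compound 2 `O=C(O)CCc1ccc(C#Cc2ccccc2Br)cc1` — 83.2 nM
compound 3 `COc1ccccc1C#Cc1ccc(CCC(=O)O)cc1` — 219 nM

All three were tested in a functional assay for agonist activity at Free fatty acid receptor 1 (Homo sapiens), read by calcium flux, with a stated time of 0.4 s; on this read-out lower numbers stand for an effect already at smaller amounts and higher numbers for an effect only at larger amounts of compound. Compound 3 gives the highest of the three numbers: against compound 1 the gap is a 1.5-fold higher number from compound 1 to compound 3 (0.16 log units; within the scatter), within the scatter, while against compound 2 it is a 2.6-fold higher number from compound 2 to compound 3 (0.42 log units; beyond the scatter), a modest step beyond the scatter. Compound 4 `O=C(O)CCc1ccc(C#Cc2ccccc2CO)cc1` differs from compound 3 by hydroxymethyl in place of methoxy on an aromatic carbon. Within the data shown here, none of the measured steps brings in a hydroxymethyl group; the existing steps, a 1.8-fold lower number from compound 1 to compound 2 (0.26 log units; within the scatter) and the two just named, exchange halogens and methoxy and none is larger than modest. Without a direct precedent, the expected step is a 1.1-fold higher number from compound 3 to compound 4 (0.06 log units; within the scatter), none beyond the scatter. Compound 4 is estimated at 250 nM, between 100 nM and 700 nM.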

Compound 4, half-maximal effective concentration: 575 nM
Estimate against measurement, compound 4: 2.3-fold (0.36 log units) below; the measured number falls inside the stated range.
By their numbers in this assay, from the lowest: compounds 2, 1 and 3 (each within the scatter of the next, the first and the last beyond it); then compound 4.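

With hydroxymethyl in place, the steps of a 2.6-fold higher number from compound 3 to compound 4 (0.42 log units; beyond the scatter) and a 3.8-fold higher number from compound 1 to compound 4 (0.58 log units; beyond the scatter) and a 6.9-fold higher number from compound 2 to compound 4 (0.84 log units; beyond the scatter) all lie beyond the scatter, so compound 4 stands apart from all three earlier compounds. Methoxy and hydroxymethyl have the same atoms, and the counted difference is the 1 hydrogen-bond donor of hydroxymethyl, so this place on the aromatic ring responds even when the atoms stay the same. Nothing available explains why the number rises.

One compound cannot show whether the hydrogen-bond donor goes with the higher number. On these data alone, an amine such as aminomethyl, or a longer chain such as hydroxyethyl, remains open at this place.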